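This account rests on a few compounds, and the source may have more. Where it says the series, first, only, none or still open, it means among the compounds named here.

For the measured compounds named here, compound 2 `CC[C@@H]1C(=O)N(C)c2cnc(-n3ccc4cc(F)ccc43)nc2N1C1CCCC1` carries the highest number of the two measured so far: in an assay for inhibition of serine/threonine-protein kinase PLK2 (Homo sapiens), read by FRET and Z'-LYTE, with a stated time of 1 h (a higher number here means a weaker inhibitor, a lower number a stronger inhibitor), compound 2 gives 969 nM, whereas compound 1 `CC[C@@H]1C(=O)N(C)c2cnc(-n3ccc4cc(C(N)=O)ccc43)nc2N1C1CCCC1` gives 28.5 nM. Compound 3 `CC[C@@H]1C(=O)N(C)c2cnc(-n3ccc4cc(C(=O)NC)ccc43)nc2N1C1CCCC1` differs from compound 2 by methylcarbamoyl in place of fluoro on an aromatic carbon. Going by the values given here, the only measured step that bears on this change is a 34-fold higher number from compound 1 to compound 2 (1.53 log units; beyond the scatter), where fluoro took the place of carbamoyl; the present change runs the other way, restoring an amide at the same position. A large step downward in this assay is therefore expected for compound 3, a 24-fold lower number from compound 2 to compound 3 (1.38 log units; beyond the scatter). Compound 3 is estimated at 40 nM, with a range from 12 nM to 130 nM.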

Compound 3, half-maximal inhibitory concentration: 8.6 nM
Estimate against measurement, compound 3: 4.7-fold (0.67 log units) above; measured number outside the range, below it.
By their numbers in this assay, from the lowest: compound 3; then compound 1; then compound 2.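

In this assay, the amide hydrogen is not needed at this position: methyl in place of it gives a 3.3-fold lower number from compound 1 to compound 3 (0.52 log units; beyond the scatter) and makes methylcarbamoyl the best group of the three. Replacing fluoro with methylcarbamoyl gives a 110-fold lower number from compound 2 to compound 3 (2.05 log units; beyond the scatter) as a large step, so this aromatic carbon strongly separates fluoro from both amides. No data given here explain either step. On these data alone, whether an ethyl or longer chain on the amide nitrogen, or a second methyl there, extends this gain remains open. So does whether a carboxylic acid or an amine at this carbon would match the amides.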